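Naphthaldehyde thiosemicarbazones: aryl substituent at the terminal nitrogen

The source may hold more compounds than are shown below. What is called first, only, known or untested is meant among the compounds shown, and "the series" means these compounds.

Measured so far in a functional assay on B16 cells (Mus musculus), read by spectrophotometry, with a stated time of 3 days; on this read-out higher numbers stand for weaker inhibition and lower numbers for stronger inhibition:
Compound 1, `CNC(=S)N/N=C/c1cccc2ccccc12`: compound 1 gives 2000 nM
Compound 2, `Cc1ccc(NC(=S)N/N=C/c2cccc3ccccc23)cc1`: compound 2 gives 580 nM
Compound 3, `Cc1cccc(NC(=S)N/N=C/c2cccc3ccccc23)c1`: compound 3 gives 450 nM

Compound 3 gives the lowest number of the three in this assay, but compound 2 sits within the scatter of it; only compound 1 stands clearly apart. Going by the values given here, replacing the methyl on the amide-type nitrogen by an aryl group is the one change that registers: a 3.4-fold lower number from compound 1 to compound 2 (0.54 log units; beyond the scatter) and a 4.4-fold lower number from compound 1 to compound 3 (0.65 log units; beyond the scatter). Moving the methyl on that aryl ring from one position to the other does not: a 1.3-fold lower number from compound 2 to compound 3 (0.11 log units; within the scatter).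

Compound 4, `COc1cccc(NC(=S)N/N=C/c2cccc3ccccc23)c1`, has not been measured in this assay. Its difference from compound 3 is methoxy in place of methyl on an aromatic carbon. Among the compounds with values here, no measured pair changes methyl to methoxy, so none of the steps above speaks to it directly; the only nearby evidence is that a small change on the aryl ring, as from compound 2 to compound 3, stayed within the scatter. The expectation for compound 4 is therefore no step beyond the scatter in this assay, in either direction. The step this estimate implies is no change at the digits printed from compound 3 to compound 4 (within the scatter), expected to lie within the scatter. For compound 4 the estimated value is 450 nM, with an expected range from 200 nM to 1000 nM.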

Compound 4, half-maximal inhibitory concentration: 830 nM
For compound 4 the middle estimate is 1.8-fold (0.27 log units) below the measured one; the range from low to high includes it.
By their numbers in this assay, from the lowest: compounds 3, 2 and 4 (each within the scatter of the next); then compound 1.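

Going by these compounds alone, the change from 3-methylphenyl to 3-methoxyphenyl, which brings one hydrogen-bond acceptor onto the aromatic ring, is the first change of group at this ring position, and in this assay it stays within the scatter (a 1.8-fold higher number from compound 3 to compound 4 (0.27 log units; within the scatter)); compound 4 likewise stays within the scatter of the 4-methylphenyl compound (a 1.4-fold higher number from compound 2 to compound 4 (0.16 log units; within the scatter)). The separation from the methyl compound carries over to a substituent containing oxygen, though as a modest step (a 2.4-fold lower number from compound 1 to compound 4 (0.38 log units; beyond the scatter)), so all three aryl compounds now stand clear of compound 1. No measurement is at hand that would explain these values.

Still open, going by these compounds, is whether a methoxy group at the other ring position gives a value in the same range. Also open, on these data alone, is whether an amine, a carboxylic acid or a chlorine atom on the aryl ring would stay within the scatter of compound 3.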